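Removing a Phenyl Ring from an Inactive Amide

The source may report more compounds than this note shows. Statements on the series, on what has been measured and on what is new or still open speak of the compounds shown alone.

Measured compounds:
compound 1, `CS(=O)(=O)c1ccc(C(=O)NCCC(=O)N2CCCCC2)cc1[N+](=O)[O-]`: > 60000 nM
compound 2, `CS(=O)(=O)c1ccc(C(=O)NCCCC(=O)N2CCC(c3ccccc3)CC2)cc1[N+](=O)[O-]`: > 60000 nM

In an assay on isolated protein for inhibition of thyroid hormone receptor beta (Homo sapiens), read by fluorescence polarization (a higher number here means a weaker inhibitor, a lower number a stronger inhibitor), compound 2 gives > 60000 nM, which is a limit of the assay and not a number. Compound 1 likewise gives > 60000 nM in this assay, again only a limit. Both values therefore share one position: the limit of > 60000 nM in this assay, at which 2 of the 2 values shown sit. Nothing in these two results separates a stronger from a weaker inhibitor, since neither compound shows measurable inhibition at the concentrations tested.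

Compound 3, `CS(=O)(=O)c1ccc(C(=O)NCCCC(=O)N2CCCCC2)cc1[N+](=O)[O-]`, is built from compound 2 by a single change: hydrogen in place of phenyl on a saturated ring carbon. Among the compounds with values here, no step between two measured compounds is available to show how such a change acts in this assay. With both measured compounds at the limit, there is no ground to expect compound 3 to move beyond the scatter in either direction. The expected step from compound 2 to compound 3 in this assay is a step that the limit leaves unreadable from compound 2 to compound 3. Compound 3 is expected to give 80000 nM in this assay, within 20000 nM to 300000 nM, most likely reported again only as a limit.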

Compound 3, half-maximal inhibitory concentration: > 60000 nM
Compound 3: a limit, no number; the forecaster's own chance of this, stated with the estimate: 85%; the middle value lies beyond the limit too.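

Neither the step from compound 2 to compound 3 nor the step from compound 1 to compound 3 can be read, since all three compounds share one position: the limit of > 60000 nM in this assay, at which 3 of the 3 values shown sit.

As far as these compounds go, whether hydrogen in place of phenyl makes any difference in this assay, and which change to the shared core would give a readable number, stays open.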